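Hydroxy on the Core: Expected Effect in Compound 4

The source may report more compounds than this note shows. Statements on the series, on what has been measured and on what is new or still open speak of the compounds shown alone.

Compound 1 `C=C1CC[C@@H]2[C@](C)(CCC[C@]2(C)C(=O)OC)[C@H]1CCc1ccc2c(OC(C)=O)ccc(OC(C)=O)c2c1`: 120 nM
Compound 2 `C=C1CC[C@@H]2[C@](C)(CCC[C@]2(C)C(=O)OC)[C@H]1CCc1ccc2c(OC)ccc(OC)c2c1`: > 6700 nM
Compound 3 `C=C1[C@H](O)C[C@@H]2[C@](C)(CCC[C@]2(C)C(=O)OC)[C@H]1CCc1ccc2c(OC(C)=O)ccc(OC(C)=O)c2c1`: 1600 nM

In a functional assay on A549 cells (Homo sapiens) for cytotoxicity, read by sulforhodamine B assay, with a stated time of 72 h (on this read-out higher numbers stand for weaker inhibition of growth and lower numbers for stronger inhibition of growth), compound 1 gives 120 nM and compound 3 gives 1600 nM. Compound 3 arises from compound 1 by hydroxy in place of hydrogen on a saturated ring carbon, and this step is a 13-fold higher number from compound 1 to compound 3 (1.12 log units; beyond the scatter). For compound 2 the value in this assay is a limit of the assay and not a number; compound 2 gives > 6700 nM. How the core of compound 2 differs from that of compound 1 is not broken down here.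

Compound 4 `C=C1[C@H](O)C[C@@H]2[C@](C)(CCC[C@]2(C)C(=O)OC)[C@H]1CCc1ccc2c(OC)ccc(OC)c2c1` has not been measured in this assay. It arises from compound 2 by hydroxy in place of hydrogen on a saturated ring carbon, the same change as from compound 1 to compound 3. Since compound 2 already sits at the limit of > 6700 nM in this assay, at which 1 of the 3 values shown sits, and the earlier step was a 13-fold higher number from compound 1 to compound 3 (1.12 log units; beyond the scatter), compound 4 is expected to weaken further, with an estimated step that the limit leaves unreadable from compound 2 to compound 4. Compound 4 is therefore estimated at 30000 nM, within 7000 nM to 150000 nM, and a limit rather than a number is the most likely outcome.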

Compound 4, concentration for 50% growth inhibition: > 6400 nM
Compound 4: only a limit was reported; the forecaster's own chance of this, stated with the estimate: 90%; the middle value is on the limit's open side.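

Compound 2 and compound 4 are each reported only as a limit and not a number, so the step between them cannot be read. As far as these compounds go, whether hydroxy in place of hydrogen weakens growth inhibition on the core of compound 2, as it does for compound 1 and compound 3, stays open.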